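This account rests on a few compounds, and the source may have more. Where it says the series, first, only, none or still open, it means among the compounds named here.

Three compounds were measured in an ADME assay on microsomes from liver (Mus musculus, strain NMRI) for metabolic stability, tested at 2.5 uM; on this read-out higher numbers stand for fast clearance and lower numbers for slow clearance. Compound 1, `Fc1ccc(-c2ccc(Cn3nnc4ccccc43)cc2)c(F)c1`, gives 2.3 mL/min/g. Compound 2, `Fc1ccc(-c2ccc(Cn3nnc4ccccc43)cc2)c(Cl)c1`, gives 1.5 mL/min/g. The two differ by chloro in place of fluoro on an aromatic carbon, and that change produced a 1.5-fold lower number from compound 1 to compound 2 (0.19 log units; within the scatter). Compound 3, `Fc1ccc(Cn2nnc3c(Br)cccc32)cc1`, gives 1 mL/min/g, the lowest of the three numbers; its gap to compound 1 lies beyond the scatter, while its value and that of compound 2 lie within the scatter of each other. How the core of compound 3 differs from the core of compound 1 is not broken down here.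

Compound 4, `Clc1ccc(Cn2nnc3c(Br)cccc32)cc1`, has not yet been measured in this assay. It differs from compound 3 by chloro in place of fluoro on an aromatic carbon. This is the same kind of change as that from compound 1 to compound 2, though the surroundings differ: in compound 1 the place is ortho to a large group and meta to a fluoro group, whereas in compound 3 it is para to a large group. From compound 3 to compound 4 the expected step is a 1.3-fold lower number from compound 3 to compound 4 (0.10 log units; within the scatter), because a 1.5-fold lower number from compound 1 to compound 2 (0.19 log units; within the scatter) was the outcome of the earlier change of this kind. Compound 4 is therefore expected to give about 0.8 mL/min/g, plausibly between 0.4 mL/min/g and 1.6 mL/min/g.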

Compound 4, intrinsic clearance in a liver preparation (reported as CLH), per the amount of preparation that the assay uses: 2 mL/min/g
Estimate against measurement, compound 4: 2.5-fold (0.40 log units) below, outside the stated range (above it).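

In this assay, chloro in place of fluoro on an aromatic carbon para to a large group gave a 2.0-fold higher number from compound 3 to compound 4 (0.30 log units; within the scatter), so this step taken alone is no firm change. Set beside the earlier step, however, the two outcomes do not agree, and the change cannot be treated as having one fixed outcome across these two cores: the same change on two cores in this assay, a 1.5-fold lower number (0.19 log units; within the scatter) from compound 1 to compound 2 and a 2.0-fold higher number (0.30 log units; within the scatter) from compound 3 to compound 4, 3.1-fold (0.49 log units) apart, beyond the scatter of two such steps

This shows that the step seen on the core of compound 1 did not carry over to the core of compound 3, but it does not show what separates the two cases. The cores differ, the surroundings of the place differ as well, and a single pair on each core cannot tell these apart.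

The compounds shown leave open how the number would move with a different group at this place, such as a methoxy group, a nitrile or an amine. Going by these compounds, whether the bromo group on the core of compound 3 bears on the outcome also stays open.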